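Cytotoxicity on a benzyloxybenzylidene iminothiazolidinone series

The compounds below may be only part of what the source reports. "The series", "measured", "known", "first", "only" and "open" are said of these compounds alone.

Measured compounds:
compound 1 `N=C1S/C(=C\c2ccc(OCc3ccccc3)cc2)C(=O)N1c1ccc(Br)cc1`, 7.83%
compound 2 `Cc1cccc(N2C(=N)S/C(=C\c3ccc(OCc4ccccc4)cc3)C2=O)n1`, 25.1%

Both were run in an ADME assay on RAW264.7 cells (Mus musculus) for cytotoxicity, read by MTT assay, with a stated time of 48 h, tested at 50 uM; a higher number here means more inhibition at the concentration tested (going by the name of the read-out), a lower number less inhibition. Compound 1 gives 7.83%, and compound 2 gives 25.1%. Compound 2 stands highest of the two numbers, its nearest neighbour being compound 1, and the step of a number 17.3 percentage points higher from compound 1 to compound 2 (beyond the scatter) shows that exchanging the aryl group on the amide-type nitrogen in the ring moves the read-out by a modest amount.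

Compound 3 `Cc1ccc(N2C(=N)S/C(=C\c3ccc(OCc4ccccc4)cc3)C2=O)c(C)c1` has not been measured yet. It differs from compound 2 in one place: 2,4-dimethylphenyl in place of 6-methylpyridin-2-yl on an amide-type nitrogen in a ring. Among the compounds with values here, the only step that bears on this change is a number 17.3 percentage points higher from compound 1 to compound 2 (beyond the scatter), where another aryl group was replaced at the same nitrogen. That step was modest, and its direction offers no guide for the present swap, since compound 3 returns to a carbon-only ring as in compound 1 while carrying methyl groups as in compound 2. A step in this assay of modest size in either direction, or none beyond the scatter, is plausible.

The expected step is a number 10.1 percentage points lower from compound 2 to compound 3 (beyond the scatter), so compound 3 is estimated at 15%, within a range from 3% to 35%.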

Compound 3, a percentage reported as inhibition, at one concentration (the size of the read-out at that concentration, not a potency): 36.8%
Compound 3: the middle estimate sits 21.8 percentage points below what was measured; the measured number lies above the stated range.
By their numbers in this assay, from the lowest: compound 1; then compound 2; then compound 3.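

In this assay, the amide-type nitrogen in the ring now carries three aryl groups, and each further change is beyond the scatter: a number 11.7 percentage points higher from compound 2 to compound 3 (beyond the scatter) with 2,4-dimethylphenyl in place of 6-methylpyridin-2-yl, and a number 29 percentage points higher from compound 1 to compound 3 (beyond the scatter) with 2,4-dimethylphenyl in place of 4-bromophenyl. The two aromatic rings of carbon only give the lowest and the highest of the three numbers, compound 1 and compound 3, with the 6-methylpyridin-2-yl group of compound 2 in the middle, so the presence of a ring nitrogen does not alone set the order among these compounds. Nothing available explains these differences.

The compounds shown leave open whether the higher number of compound 3 needs both methyl groups of 2,4-dimethylphenyl or follows from one of them, as no single-methyl phenyl ring stands among them. They also leave open how a carboxylic acid or an amine on that aryl ring, or a longer alkyl chain in its place at the same nitrogen, would read out at this one tested concentration.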